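The source may hold more compounds than are shown below. What is called first, only, known or untested is meant among the compounds shown, and "the series" means these compounds.

Measured compounds:
Compound 1 `O=C1COCC(=O)N1CCCCN1CCN(c2ncccc2-c2ccccc2)CC1`: 16 nM in an assay on isolated protein for binding affinity to Adrenergic receptor alpha-1 (Rattus norvegicus); a higher number here means a weaker inhibitor, a lower number a stronger inhibitor
Compound 2 `COC(=O)c1cccnc1N1CCN(CCCCN2C(=O)SC3(CCCC3)C2=O)CC1`: 7.8 nM in this assay

Of the two compounds with numbers, compound 2 has the lower one, and the gap to compound 1 lies beyond the usual scatter, so compound 2 stands as the stronger of the pair in this assay. Among the compounds with values here, no step between these two has been computed, as they differ in more than one place.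

Compound 3 `O=C1SC2(CCCC2)C(=O)N1CCCCN1CCN(c2ncccc2[N+](=O)[O-])CC1` has not yet been measured. It differs from compound 2 in a single place: nitro in place of methoxycarbonyl on an aromatic carbon. In both compounds the group at this place sits on an aromatic carbon of a six-membered aromatic ring with one nitrogen, ortho to a large group and two atoms from the ring nitrogen, and both groups carry two hydrogen-bond acceptors and no donor.

Within the data shown here, with no measured step of this kind to lean on, the expected change for compound 3 in this assay is small, with no clear direction and none beyond the scatter; the estimated step is a 1.3-fold higher number from compound 2 to compound 3 (0.11 log units; within the scatter). Compound 3 is expected to give about 10 nM, with a range from 3 nM to 35 nM.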

Compound 3, half-maximal inhibitory concentration: 34.1 nM
The estimate for compound 3 lay 3.4-fold (0.53 log units) below the measured number; measured number inside the range.
By their numbers in this assay, from the lowest: compound 2; then compound 1; then compound 3.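

Within the data shown here, compound 2 and compound 3 gave the first measured step at this place, on an aromatic carbon of a six-membered aromatic ring with 1 nitrogen, ortho to a large group and two atoms from the ring nitrogen. Going from 3-(methoxycarbonyl)pyridin-2-yl to 3-nitropyridin-2-yl gives in this assay a 4.4-fold higher number from compound 2 to compound 3 (0.64 log units; beyond the scatter), so the number at this place depends on which of these two groups it carries, even though they match in hydrogen-bond donors, hydrogen-bond acceptors and net charge. Nothing measured here accounts for the size of this step.

The compounds shown leave open how a carboxylic acid, a primary amide or an amine at this same place would read in this assay, and whether plain hydrogen there would give a number closer to that of compound 2 or that of compound 3. With a single pair behind this step, they also leave open whether nitro in place of methoxycarbonyl would shift the number in the same way with a different group at the far end of the butyl chain.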